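The compounds below may be only part of what the source reports. "The series", "measured", "known", "first", "only" and "open" are said of these compounds alone.

In a functional assay on PANC-1 cells (Homo sapiens) for cytotoxicity, read by resazurin assay, with a stated time of 48 h (a higher number here means a weaker inhibitor, a lower number a stronger inhibitor), three compounds have been measured so far:

Compound 1 `CCOc1ccc(NC(=O)c2c(N)n[nH]c2Nc2ccccc2)cc1` gives 21000 nM.
Compound 2 `C=CCNc1[nH]nc2nnn(-c3ccc(OCC)cc3)c(=O)c12` gives 13300 nM.
Compound 3 `CCOc1ccc(NC(=O)CC#N)cc1` gives 43900 nM.

Among these three numbers, compound 2 has the lowest. Compound 1 is nearest to it, and the gap between compound 2 and compound 1 lies within the usual scatter of this kind of measurement, so the two cannot be told apart on these data. Compound 3 is furthest from compound 2, and that gap is beyond the scatter, so compound 3 is the weaker of the pair in this assay.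

The next compound is compound 4 `CCOc1ccc(-n2nnc3n[nH]c(Nc4ccccc4)c3c2=O)cc1`, which has not yet been tested. It keeps the core of compound 2 and differs from it in one place: phenyl in place of allyl on a nitrogen on an aromatic ring. Going by the values given here, no pair of measured compounds differing in one place is available here, so there is no measured step on which to lean, and nothing in the data ties this change to any direction in this assay. The expectation is therefore that the step of a 1.1-fold lower number from compound 2 to compound 4 (0.04 log units; within the scatter) stays within the scatter, in neither direction beyond it. On that basis compound 4 is estimated at 12000 nM, with a range from 4500 nM to 32000 nM.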

Compound 4, half-maximal inhibitory concentration: 13100 nM
Estimate against measurement, compound 4: 1.1-fold (0.04 log units) below, and the stated range covers the measured number.
By their numbers in this assay, from the lowest: compounds 4, 2 and 1 (each within the scatter of the next); then compound 3.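

In this assay, going by these compounds alone, the only measured step at this position is phenyl in place of allyl on a nitrogen on an aromatic ring, the allylamino to anilino change, and it gives a 1.0-fold lower number from compound 2 to compound 4 (0.01 log units; within the scatter). At this place, then, a phenyl with its six-membered aromatic ring and 6 heavy atoms can stand in for an allyl with 3 heavy atoms and a double bond, and the assay does not tell the two compounds apart, so neither the larger group nor the ring shifts the number beyond the scatter here. No measurement is available that bears on why the two compounds read alike. From the compounds shown here alone, both groups contain carbon only and carry no hydrogen-bond donors or acceptors, so it stays open whether an amine, a carboxylic acid or a hydroxyl on this nitrogen would leave the number where it is, and the same holds for a longer chain such as hexyl. Going by these compounds, it is also open whether any group here could move the number beyond the scatter, since a single step at one position cannot show how far this place tolerates change.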